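The source may report more compounds than this note shows. Statements on the series, on what has been measured and on what is new or still open speak of the compounds shown alone.

For the measured compounds named here, in a functional assay on A-431 cells (Homo sapiens) for cytotoxicity, read by MTT assay, with a stated time of 72 h, tested at 30 uM (on this read-out higher numbers stand for more inhibition of growth at the one concentration tested and lower numbers for less inhibition of growth), compound 2 `N/C(=N\NC(=S)N1CCCCC1)c1ccccn1` gives 79.7%, the second highest of the three numbers so far: compound 1 `N/C(=N\NC(=S)N1CCCC1)c1ccc(F)cn1` gives 83.3%, within the scatter of compound 2, while compound 3 `Cc1cccc(/C(N)=N/NC(=S)N2CCCCC2)n1` gives 65.2%, the step of a number 14.5 percentage points lower from compound 2 to compound 3 (beyond the scatter) being the only one beyond the scatter. Compound 4 `N/C(=N\NC(=S)N1CCCC1)c1ccccn1` differs from compound 2 by pyrrolidin-1-yl in place of piperidin-1-yl on a thiocarbonyl carbon. Going by the values given here, no measured step concerns this ring exchange; the single step known involves a methyl on an aromatic carbon, so it bears on compound 4 only indirectly. Compound 1, which already carries the pyrrolidin-1-yl group, sits within the scatter of compound 2, so for compound 4 no step beyond the scatter is expected, a number 1.3 percentage points higher from compound 2 to compound 4 (within the scatter). Compound 4 is therefore estimated at 81%, between 70% and 90%.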

Compound 4, percent growth inhibition at one concentration: 85.2%
For compound 4 the middle estimate is 4.2 percentage points below the measured one; the range from low to high includes it.
By their numbers in this assay, from the lowest: compound 3; then compounds 2, 1 and 4 (each within the scatter of the next).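

On the thiocarbonyl carbon, pyrrolidin-1-yl in place of piperidin-1-yl gives a number 5.5 percentage points higher from compound 2 to compound 4 (within the scatter) in this assay, so this assay does not separate the two rings on the unsubstituted core. Hydrogen in place of fluoro on an aromatic carbon gives a number 1.9 percentage points higher from compound 1 to compound 4 (within the scatter) and so is not separated either. Nothing available gives a cause for these two steps.

From the compounds shown here alone, whether a morpholine ring or an open-chain dimethylamino group on the thiocarbonyl carbon would keep this level stays open. So does the effect of a chloro or methoxy group in place of fluoro.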